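Shifting a methyl group from compound 3 to compound 4

A few compounds are considered here, and "the series" means these few. Any claim that something is new, unique, unknown or untested is made for them only; others in the source may bear on it.

Compound 1 `O=c1c(O)cccn1Cc1ccccc1` carries the core of this small series. In an ADME assay on THP-1 cells (Homo sapiens) for cytotoxicity, read by resazurin assay, with a stated time of 48 h (a lower number here means a stronger inhibitor, a higher number a weaker inhibitor), compound 1 gives > 10 ug/mL, which is a limit and not a number. Compound 2 `N#Cc1ccccc1-c1ccc(Cn2cccc(O)c2=O)cc1` gives > 10 ug/mL, also a limit. Going by these compounds, compound 3 `Cc1ccc(-c2ccc(Cn3cccc(O)c3=O)cc2)cc1` gives > 10 ug/mL, again a limit, so its true standing is unknown. All the data sit at one point: the limit of > 10 ug/mL in this assay, at which 3 of the 3 values shown sit. Within the data shown here, the only measured step that bears on the change is a step that the two limits leave unreadable from compound 1 to compound 3.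

Compound 4 `Cc1ccccc1-c1ccc(Cn2cccc(O)c2=O)cc1` has 2-methylphenyl in place of 4-methylphenyl on an aromatic carbon. With no readable step as a guide, no shift beyond the scatter is expected, and the estimated step is a step that the limit leaves unreadable from compound 3 to compound 4. For compound 4 the expected value in this assay is 20 ug/mL, with an estimated range of 10 ug/mL to 50 ug/mL.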

Compound 4, half-maximal inhibitory concentration: > 10 ug/mL
Compound 4 was reported as a limit; the forecaster's own chance of this, stated with the estimate: 85%; the middle value does not contradict the limit.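

Compound 4, like compound 1, compound 2 and compound 3, is reported only as a limit, so no step among them can be read, because all share one point: the limit of > 10 ug/mL in this assay, at which 4 of the 4 values shown sit.

Going by these compounds, the true value of each compound stays open, and so does whether 2-methylphenyl and 4-methylphenyl differ at all.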